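This account rests on a few compounds, and the source may have more. Where it says the series, first, only, none or still open, it means among the compounds named here.

Measured compounds in a functional assay on BT-474 cells (Homo sapiens) for inhibition, read by fluorescence, with a stated time of 72 h; on this read-out higher numbers stand for weaker inhibition of growth and lower numbers for stronger inhibition of growth:
compound 1 `CC(C)CCn1cnc2c(Nc3cccc(Cl)c3)nc(N[C@H]3CC[C@H](N)CC3)nc21` gives 3800 nM
compound 2 `CC(C)CCn1cnc2c(Nc3ccccc3)nc(N[C@H]3CC[C@H](N)CC3)nc21` gives 6400 nM
compound 3 `CCCCn1cnc2c(Nc3cccc(Cl)c3)nc(N[C@H]3CC[C@H](N)CC3)nc21` gives 5100 nM

Compound 2 differs from compound 1 by hydrogen in place of chloro on an aromatic carbon, and in this assay that change gave a 1.7-fold higher number from compound 1 to compound 2 (0.23 log units; within the scatter). The core of compound 3 differs from the core of compound 1 by hydrogen in place of methyl on a saturated chain carbon bound to two saturated chain carbons, which gave a 1.3-fold higher number from compound 1 to compound 3 (0.13 log units; within the scatter). Compound 4 `CCCCn1cnc2c(Nc3ccccc3)nc(N[C@H]3CC[C@H](N)CC3)nc21` has not yet been measured. It differs from compound 3 by hydrogen in place of chloro on an aromatic carbon, the same change that was made from compound 1 to compound 2. Beside that earlier step, the step expected from compound 3 to compound 4 in this assay is a 1.7-fold higher number from compound 3 to compound 4 (0.23 log units; within the scatter), because a 1.7-fold higher number from compound 1 to compound 2 (0.23 log units; within the scatter) is the only observation of this change on a closely related core and the two starting values lie within the scatter of each other. Compound 4 is therefore estimated at 8700 nM, expected to fall between 4300 nM and 18000 nM.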

Compound 4, concentration for 50% growth inhibition: 4900 nM
Beside the measured number, compound 4's estimate is 1.8-fold (0.25 log units) above it; low and high end bracket the measured number.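

Hydrogen in place of chloro on an aromatic carbon gave a 1.0-fold lower number from compound 3 to compound 4 (0.02 log units; within the scatter), and this step does not differ from the earlier one beyond the scatter: the same change on two cores in this assay, a 1.7-fold higher number (0.23 log units; within the scatter) from compound 1 to compound 2 and a 1.0-fold lower number (0.02 log units; within the scatter) from compound 3 to compound 4, 1.8-fold (0.24 log units) apart, within the scatter of two such steps. Hydrogen in place of methyl on a saturated chain carbon bound to two saturated chain carbons gave a 1.3-fold lower number from compound 2 to compound 4 (0.12 log units; within the scatter), and this comparison likewise shows no difference beyond the scatter: the same change on two cores in this assay, a 1.3-fold higher number (0.13 log units; within the scatter) from compound 1 to compound 3 and a 1.3-fold lower number (0.12 log units; within the scatter) from compound 2 to compound 4, 1.8-fold (0.24 log units) apart, within the scatter of two such steps. All these steps lie within the scatter in this assay, so the four compounds give no sign that either change depends on the core, but they do not show that either change has an effect of its own to carry over.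

The compounds shown leave open whether a different group on the aromatic ring, such as a methoxy group or a nitrile, would give a step beyond the scatter. They also leave open whether a longer chain, or a chain ending in an amine or a carboxylic acid, would do so.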